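Triazole aryl swap: bromophenyl to methylphenyl

A few compounds are considered here, and "the series" means these few. Any claim that something is new, unique, unknown or untested is made for them only; others in the source may bear on it.

The series shares one core: compound 1 `CC1(C)[C@H]2CC[C@]1(C)N(Cc1cn(-c3ccc(Cl)cc3)nn1)C(=O)C2`, compound 2 `CC1(C)[C@H]2CC[C@]1(C)N(Cc1cn(-c3ccc(F)cc3)nn1)C(=O)C2` and compound 3 `CC1(C)[C@H]2CC[C@]1(C)N(Cc1cn(-c3ccc(Br)cc3)nn1)C(=O)C2` differ only in the halogen on the phenyl. In a functional assay on PANC-1 cells (Homo sapiens) for inhibition, read by MTT assay, with a stated time of 24 h (on this read-out lower numbers stand for stronger inhibition and higher numbers for weaker inhibition), compound 1 gives 440 nM, compound 2 gives 110 nM and compound 3 gives 200 nM, the second highest number of the three. The steps of a 4.0-fold lower number from compound 1 to compound 2 (0.60 log units; beyond the scatter) and a 2.2-fold lower number from compound 1 to compound 3 (0.34 log units; beyond the scatter) are modest; a 1.8-fold higher number from compound 2 to compound 3 (0.26 log units; within the scatter). Compound 4 `Cc1cccc(-n2cc(CN3C(=O)C[C@@H]4CC[C@@]3(C)C4(C)C)nn2)c1` carries the change (3-methylphenyl in place of 4-bromophenyl on an aromatic nitrogen). Among the compounds with values here, no measured step exchanges a halogen for a methyl or moves the group around the ring, so the halogen steps bear only loosely; none of them exceeded a modest size. A step within or near the scatter is therefore expected, a 1.3-fold higher number from compound 3 to compound 4 (0.10 log units; within the scatter). Compound 4 is expected at 250 nM, with a range from 100 nM to 600 nM.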

Compound 4, half-maximal inhibitory concentration: 240 nM
Estimate against measurement, compound 4: 1.0-fold (0.02 log units) above, and the stated range covers the measured number.
By their numbers in this assay, from the lowest: compounds 2, 3, 4 and 1 (each within the scatter of the next, the first and the last beyond it).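

In this assay, the step to 3-methylphenyl on the aromatic nitrogen gives a 1.2-fold higher number from compound 3 to compound 4 (0.08 log units; within the scatter) and so stays within the scatter, showing that this position tolerates a carbon-only substituent in place of 4-bromophenyl. The comparison with 4-fluorophenyl gives a 2.2-fold higher number from compound 2 to compound 4 (0.34 log units; beyond the scatter) and the one with 4-chlorophenyl gives a 1.8-fold lower number from compound 1 to compound 4 (0.26 log units; within the scatter) with only the first beyond the scatter. No evidence on the cause of these numbers is available here.

This change replaces the halogen and shifts the ring position together, so the two contributions remain unseparated. Going by these compounds, how an amine or a carboxylic acid on the phenyl would read remains open.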